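This account rests on a few compounds, and the source may have more. Where it says the series, first, only, none or still open, it means among the compounds named here.

Among the measured compounds shown here, in a functional assay on HeLa cells (Homo sapiens) for cytotoxicity, read by MTT assay, with a stated time of 48 h (on this read-out lower numbers stand for an effect already at smaller amounts and higher numbers for an effect only at larger amounts of compound), two compounds built on a shared core have numbers so far. Compound 1 `CS(=O)(=O)c1ccc(Cc2n[nH]c(=S)n2/N=C/c2c(F)cccc2Cl)cc1` gives 25000 nM, while compound 2 `CS(=O)(=O)c1ccc(Cc2n[nH]c(=S)n2/N=C/c2ccc(F)cc2)cc1` gives 100000 nM, the higher of the two numbers. Compound 2 therefore needs the larger amount to show an effect. A single measured step links them: a 4.0-fold higher number from compound 1 to compound 2 (0.60 log units; beyond the scatter), with 4-fluorophenyl in place of 2-chloro-6-fluorophenyl on a carbon with a double bond to nitrogen. Compound 3 `CS(=O)(=O)c1ccc(Cc2n[nH]c(=S)n2/N=C/c2ccccc2F)cc1` has not yet been measured. It differs from compound 2 at that same carbon: 2-fluorophenyl in place of 4-fluorophenyl on a carbon with a double bond to nitrogen. The two have the same atoms, joined differently. For the measured compounds named here, no measured step shows this exact swap, so the one modest step above is the only guide, and it sets a rough scale rather than a rule. The 2-fluorophenyl name shares more with the group of compound 1, at 25000 nM, than 4-fluorophenyl does, which points towards lower numbers. In this assay, the expected change is therefore a modest drop, a 2.2-fold lower number from compound 2 to compound 3 (0.35 log units; beyond the scatter). For compound 3, the estimated value is 45000 nM, with an expected range from 18000 nM to 110000 nM.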

Compound 3, half-maximal effective concentration: > 100000 nM
Compound 3: no number, only a limit; the forecaster's own chance of this, stated with the estimate: 20%; at least 2.2-fold (0.34 log units) between middle value and limit.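

In this assay compound 3 gives a limit and not a number: the limit of > 100000 nM in this assay, at which 1 of the 3 values shown sits. Swapping 4-fluorophenyl for 2-fluorophenyl on a carbon with a double bond to nitrogen gives a number no lower from compound 2 to compound 3 (the limit leaves the size open), so this swap shows no sign of the lower number that the shared name with compound 1 had pointed to, although the size of the change cannot be read. The clearer result is an at least 4.0-fold higher number from compound 1 to compound 3 (0.60 log units; beyond the scatter), with hydrogen in place of chloro on an aromatic carbon, which shows that the fluoro group of the 2-fluorophenyl ring does not by itself keep the lower number of compound 1, and that losing the chloro group alone is enough to raise the number.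

The compounds shown leave open whether a 2-chlorophenyl group without any fluoro would hold the lower number, or whether the chloro group needs the fluoro group with it. They also leave open how a phenyl ring carrying an amine or a carboxylic acid would read at this carbon.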